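A few compounds are considered here, and "the series" means these few. Any claim that something is new, unique, unknown or untested is made for them only; others in the source may bear on it.

Working notes on the series. In an ADME assay on HEK-293T cells (Homo sapiens) for inhibition, read by CCK-8 assay, with a stated time of 48 h, tested at 20 uM (on this read-out higher numbers stand for more inhibition of growth at the one concentration tested and lower numbers for less inhibition of growth), compound 1 `N#C/C(=C\c1ccccc1OS(=O)(=O)c1ccc([N+](=O)[O-])cc1)C(=O)Nc1nnc(Cc2ccccc2)s1` is recorded as "not toxic" (no number reported) with no number attached. For the measured compounds named here, compound 2 `N#C/C(=C\c1ccccc1OS(=O)(=O)c1ccc(Cl)cc1)C(=O)Nc1nnc(-c2cccc(F)c2)s1` gives 29% in the same test, the only number so far, so it cannot yet be ranked against another value. Compound 3 `N#C/C(=C\c1ccccc1OS(=O)(=O)c1ccc(Cl)cc1)C(=O)Nc1nnc(Cc2ccc(Cl)cc2)s1` is still unmeasured and departs from compound 2 by 4-chlorobenzyl in place of 3-fluorophenyl on an aromatic carbon with 4-chlorobenzyl in place of 3-fluorophenyl on an aromatic carbon. Going by the values given here, no measured step between two compounds exists to size this change. Compound 1 at "not toxic" (no number reported) hints weakly at a lower number, yet it differs from compound 3 in more than one place. The expected change is small: the estimated a number 4 percentage points lower from compound 2 to compound 3 (within the scatter) leans toward less inhibition of growth and stays within the scatter. For compound 3 the estimated value in this assay is 25% with an expected range from 8% to 45% at the single concentration tested.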

Compound 3, percent growth inhibition at one concentration: 14%
Compound 3: the middle estimate sits 11 percentage points above what was measured; measured number inside the range.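

For the compounds shown here, this is the first measured step at this position, the aromatic carbon next to the ring nitrogen and next to the ring sulfur. In this assay, 4-chlorobenzyl in place of 3-fluorophenyl gives a number 15 percentage points lower from compound 2 to compound 3 (beyond the scatter). The group held here can therefore move growth inhibition beyond the usual scatter, though the step is only modest. No measurement at hand accounts for this change.

On these data alone, the step alters the ring's link to the shared core and the halogen together, so it remains open whether it follows the change from phenyl to benzyl or the change of halogen; 4-chlorophenyl and 3-fluorobenzyl at this position would separate the two. Also open, as far as these compounds go, is how an amine or a carboxylic acid on this carbon would read in this assay.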